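This account rests on a few compounds, and the source may have more. Where it says the series, first, only, none or still open, it means among the compounds named here.

Working notes on the series. Of the compounds shown here, three on a shared core have been measured in a functional assay on KM12 cells (Homo sapiens) for inhibition, read by sulforhodamine B assay, with a stated time of 48 h; on this read-out higher numbers stand for weaker inhibition of growth and lower numbers for stronger inhibition of growth. Compound 1 `O=C(Nc1cccc(-n2cc(-c3ccncc3)c(-c3ccc(Cl)c(O)c3)n2)c1)Nc1cccc(C(F)(F)F)c1` gives 1330 nM, compound 2 `O=C(Nc1cccc(-n2cc(-c3ccncc3)c(-c3ccc(Cl)c(O)c3)n2)c1)Nc1ccc(Cl)c(Cl)c1` gives 1010 nM, and compound 3 `COc1cc(-c2nn(-c3cccc(NC(=O)Nc4ccc(Cl)c(C(F)(F)F)c4)c3)cc2-c2ccncc2)ccc1Cl` gives 1060 nM. On these numbers compound 3 stands second highest of the three, with compound 2 nearest and compound 1 furthest, both within the scatter. Among the measured compounds shown here, the one step within the set, a 1.3-fold lower number from compound 1 to compound 2 (0.12 log units; within the scatter), exchanged the aryl group on an amide-type nitrogen and stayed within the scatter. Compound 4 `O=C(Nc1cccc(-n2cc(-c3ccncc3)c(-c3ccc(Cl)c(O)c3)n2)c1)Nc1ccc(Cl)c(C(F)(F)F)c1` differs from compound 3 by hydrogen in place of methyl on an oxygen on an aromatic ring, methoxy to hydroxy. For the measured compounds named here, no measured step covers this exchange; compounds 1 and 2 carry the hydroxy group with other aryl groups and sit within the scatter of compound 3. In this assay a step of a 1.0-fold higher number from compound 3 to compound 4 (0.02 log units; within the scatter) is therefore expected, none beyond the scatter. Compound 4 is estimated at 1100 nM, with a range from 450 nM to 2700 nM.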

Compound 4, concentration for 50% growth inhibition: 1000 nM
For compound 4 the middle estimate is 1.1-fold (0.04 log units) above the measured one; the range from low to high includes it.
By their numbers in this assay, from the lowest: compounds 4, 2, 3 and 1 (each within the scatter of the next).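

In this assay, among the compounds shown here, the step of a 1.1-fold lower number from compound 3 to compound 4 (0.03 log units; within the scatter) is the first measured one for methoxy to hydroxy, and it stays within the scatter. The two steps of a 1.0-fold lower number from compound 2 to compound 4 (0.00 log units; within the scatter) for trifluoromethyl in place of chloro and a 1.3-fold lower number from compound 1 to compound 4 (0.12 log units; within the scatter) for chloro in place of hydrogen on an aromatic carbon also stay within the scatter. No evidence on the reason for these results is at hand.

All four compounds lie within the scatter of one another, so no step beyond it is shown. Open, from the compounds shown here alone, is whether a longer chain such as ethoxy on this oxygen, or an amine or a carboxylic acid in place of hydroxy, would change the number beyond the scatter.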